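This account rests on a few compounds, and the source may have more. Where it says the series, first, only, none or still open, it means among the compounds named here.

Measured in an ADME assay on HEK293 cells (Homo sapiens) for cytotoxicity, read by fluorescence and resazurin assay, with a stated time of 24 h; a lower number here means that less compound is tolerated, a higher number that more compound is tolerated:
- compound 1 `O=S1(=O)C=C(Sc2nnc(C3CCCCC3)o2)c2ccccc21`: 3000 nM
- compound 2 `COC(=O)c1ccc(-c2nnc(SC3=CS(=O)(=O)c4ccccc43)o2)cc1`: 4000 nM
- compound 3 `O=S1(=O)C=C(Sc2nnc(-c3ccccc3Cl)o2)c2ccccc21`: 4000 nM

Compound 3 stands at 4000 nM, the same number at the digits given as compound 2 at 4000 nM. The next compound, compound 4 `O=S1(=O)C=C(Sc2nnc(-c3ccc(Cl)cc3)o2)c2ccccc21`, has 4-chlorophenyl in place of 2-chlorophenyl on an aromatic carbon of a five-membered aromatic ring with 2 nitrogen and 1 oxygen: 4-chlorophenyl in place of 2-chlorophenyl on an aromatic carbon. The two share the same atoms, joined differently.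

Within the data shown here, only one measured step bears on this change: a 1.3-fold higher number from compound 1 to compound 3 (0.12 log units; within the scatter). That step exchanges cyclohexyl for 2-chlorophenyl at the same place and stays within the scatter. Among the measured compounds shown here, no measured pair compares the two chlorophenyl groups directly, so the evidence is indirect. No shift beyond the scatter is expected in this assay, and the expected step, no change at the digits printed from compound 3 to compound 4 (within the scatter), is small. For compound 4 the estimate is 4000 nM, with an expected range of 2000 nM to 8000 nM.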

Compound 4, half-maximal cytotoxic concentration: 3000 nM
The estimate for compound 4 lay 1.3-fold (0.12 log units) above the measured number; the range from low to high includes it.
By their numbers in this assay, from the lowest: compounds 1, 4, 2 and 3 (each within the scatter of the next).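

In this assay, among these compounds, 4-chlorophenyl in place of 2-chlorophenyl on the aromatic carbon of the five-membered ring gives a 1.3-fold lower number from compound 3 to compound 4 (0.12 log units; within the scatter), the first direct comparison of the two chlorophenyl groups, so the place of the chlorine on this phenyl ring makes no readable difference here. Chloro in place of methoxycarbonyl gives a 1.3-fold lower number from compound 2 to compound 4 (0.12 log units; within the scatter), and 4-chlorophenyl in place of cyclohexyl gives no change at the digits printed from compound 1 to compound 4 (within the scatter), which means that every exchange compared so far at this position, aromatic or saturated, stays within the scatter. No measurement at hand accounts for this flat picture.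

Open, as far as these compounds go, is whether an amine, a carboxylic acid or a longer alkyl chain at this position would move the number beyond the scatter. Also open, from the compounds shown here alone, is whether any change to the shared core would do so.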